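A few compounds are considered here, and "the series" means these few. Any claim that something is new, unique, unknown or untested is made for them only; others in the source may bear on it.

Compound 1 `COc1ccc([C@H]2CC(=O)N(Cc3cccc(N)c3)C2)cc1OC1CCCC1` carries a 3-aminobenzyl on the amide-type nitrogen in the ring of the shared core. In a functional assay on HEK293 cells (Homo sapiens) for cytotoxicity (a higher number here means that more compound is tolerated, a lower number that less compound is tolerated), compound 1 gives > 10000 nM, which is a limit of the assay and not a number. Compound 1 therefore stands only at a limit, and the two further values shown for this series are limits as well. Compound 2 `COc1ccc([C@H]2CC(=O)N(C(=O)c3ccccc3)C2)cc1OC1CCCC1` bears a benzoyl on the same amide-type nitrogen in a ring; in this assay compound 2 gives > 10000 nM, again a limit. Compound 3 `COc1ccc([C@H]2CC(=O)N(c3ccccc3C(F)(F)F)C2)cc1OC1CCCC1` bears a 2-(trifluoromethyl)phenyl there; in this assay compound 3 gives > 10000 nM, likewise a limit. The steps a step that the two limits leave unreadable from compound 1 to compound 2, a step that the two limits leave unreadable from compound 1 to compound 3 and a step that the two limits leave unreadable from compound 2 to compound 3 cannot be read in size, because of the limit of > 10000 nM in this assay, at which 3 of the 3 values shown sit.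

Compound 4 `COc1ccc([C@H]2CC(=O)N(c3ccncc3)C2)cc1OC1CCCC1` remains to be measured. pyridin-4-yl in place of 3-aminobenzyl on an amide-type nitrogen in a ring None of the three measured steps gives a readable size, so no direction beyond the scatter can be drawn from them; the expectation is simply that compound 4 sits where all measured members sit. For compound 4 in this assay the expected value is 15000 nM, with a range from 7000 nM to 40000 nM. The step so expected is a step that the limit leaves unreadable from compound 1 to compound 4, most likely reported again only as a limit.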

Compound 4, half-maximal cytotoxic concentration: > 10000 nM
Compound 4: only a limit was reported; the forecaster's own chance of this, stated with the estimate: 75%; the middle value lies beyond the limit too.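

The steps joining compound 4 to compound 1, compound 2 and compound 3 in this assay cannot be read in size, because all of these values are limits and not numbers: the limit of > 10000 nM in this assay, at which 4 of the 4 values shown sit.

The compounds shown leave open how the four groups on the amide-type nitrogen in a ring rank, and whether any group there would give a numerical half-maximal cytotoxic concentration.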